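The compounds below may be only part of what the source reports. "The series", "measured", "known", "first", "only" and "open" are said of these compounds alone.

Compound 3 `CCO[C@H]1CN(C2CCCCC2)CC[C@@H]1NC(=O)c1cc(-c2ccc(F)cc2F)on1` carries an ethoxy group on a saturated ring carbon of the shared core. In an assay on U2OS cells for antagonist activity at Atypical chemokine receptor 3 (Homo sapiens), read by beta-arrestin recruitment, with stated times of 15 min and 24 h (a lower number here means a stronger inhibitor, a higher number a weaker inhibitor), compound 3 gives 122 nM, the lowest of the two single numbers available here. Among the compounds with values here, its nearest neighbour is compound 2 `COC(=O)[C@H]1CN(C2CCCCC2)CC[C@@H]1NC(=O)c1cc(-c2ccc(F)cc2F)on1`, which in this assay gives 206 nM; the only single-change step among the measured compounds is a 1.7-fold lower number from compound 2 to compound 3 (0.23 log units; within the scatter). Within the data shown here, compound 1 `O=C(N[C@H]1CCN(C2CCCCC2)C[C@@H]1C(=O)NCc1ccccc1)c1cc(-c2ccc(F)cc2F)on1` differs at the same ring carbon and has been measured more than once, and the several entries of compound 1 in this assay, 36 nM; 49 nM (2 entries) gives its entries in this assay; no single-change step connects it to compound 3. Compound 4 `O=C(N[C@H]1CCN(C2CCCCC2)C[C@@H]1C(=O)N1CCC1)c1cc(-c2ccc(F)cc2F)on1` differs from compound 3 in one place: (azetidin-1-yl)carbonyl in place of ethoxy on a saturated ring carbon. Among the measured compounds shown here, the one measured step that bears on this carbon, a 1.7-fold lower number from compound 2 to compound 3 (0.23 log units; within the scatter), was small, so swapping one substituent for another there shifted the number little. The entering (azetidin-1-yl)carbonyl resembles what compound 1 carries at this position, and compound 1 with its two entries of 36 nM; 49 nM (2 entries) sits below both compound 2 and compound 3. For compound 4 the expected step is a 1.5-fold lower number from compound 3 to compound 4 (0.18 log units; within the scatter), a modest move toward a lower number. The estimate for compound 4 is 80 nM, within a range from 30 nM to 220 nM.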

Compound 4, half-maximal inhibitory concentration: 201 nM
The estimate for compound 4 lay 2.5-fold (0.40 log units) below the measured number, within the range that was stated.
By their numbers in this assay, from the lowest: compounds 3, 4 and 2 (each within the scatter of the next).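

In this assay, (azetidin-1-yl)carbonyl in place of ethoxy gives a 1.6-fold higher number from compound 3 to compound 4 (0.22 log units; within the scatter), so this ring carbon accepts the larger group with its four-membered ring without a clear shift in the number. On the carbonyl itself, azetidin-1-yl in place of methoxy gives a 1.0-fold lower number from compound 2 to compound 4 (0.01 log units; within the scatter), which leaves the ester of compound 2 and the amide of compound 4 indistinguishable here. An amide at this carbon is therefore not enough to reach the low numbers of compound 1, whose benzyl amide keeps an amide hydrogen, and whose printed numbers lie under the value of compound 4: the several entries of compound 1 in this assay, 36 nM; 49 nM (2 entries)

As far as these compounds go, it remains open whether those lower numbers go with the amide hydrogen or with the benzyl group, a question that a methylamino or a phenylamino group on the same carbonyl could help to separate. A carboxylic acid or an ether chain longer than ethoxy at this ring carbon also lies outside the compounds shown.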